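Amino in Place of Methyl on the Shared Core

A few compounds are considered here, and "the series" means these few. Any claim that something is new, unique, unknown or untested is made for them only; others in the source may bear on it.

Compound 1, `Nc1nnc(SCc2cc(=O)c3ccccc3o2)s1`, in a functional assay on SW480 cells (Homo sapiens) for cytotoxicity, read by MTT assay, with a stated time of 72 h; on this read-out lower numbers stand for stronger inhibition and higher numbers for weaker inhibition: > 25000 nM, a limit of the assay.
Compound 2, `Nc1nnc(SCc2cc(=O)c3cc(Cl)ccc3o2)s1`, in this assay: > 25000 nM, a limit of the assay.
Compound 3, `Cc1ccc2oc(CSc3nnc(C)s3)cc(=O)c2c1`, in this assay: > 25000 nM, a limit of the assay.

Compound 3 thus stands at the assay limit, and the two further values shown are limits as well (the limit of > 25000 nM in this assay, at which 3 of the 3 values shown sit). The step from compound 1 to compound 2 is a step that the two limits leave unreadable from compound 1 to compound 2. Compound 4, `Cc1ccc2oc(CSc3nnc(N)s3)cc(=O)c2c1`, differs from compound 3 by amino in place of methyl on an aromatic carbon. Going by the values given here, no measured step bears directly on this change. Compound 1, which already carries the amino group on the same ring, also sits at the limit, > 25000 nM. Compound 4 is therefore expected to stay at the limit too, estimated at 40000 nM with a range of 15000 nM to 150000 nM. The expected step that the limit leaves unreadable from compound 3 to compound 4 is accordingly none beyond the scatter.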

Compound 4, half-maximal inhibitory concentration: > 25000 nM
Compound 4 ended at the assay's limit; the forecaster's own chance of this, stated with the estimate: 85%; the middle value lies beyond the limit too.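

In this assay, going by these compounds alone, compound 4 gives > 25000 nM as a limit of the assay, so no step among compound 1, compound 2, compound 3 and compound 4 can be read. The compounds shown leave open whether any change on the shared core brings a value inside that limit.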